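One Iodo Compound, Drawn Without a Double-Bond Configuration

This account rests on a few compounds, and the source may have more. Where it says the series, first, only, none or still open, it means among the compounds named here.

- compound 1 `C/C(=N\NC(=S)Nc1ccc(Cl)cc1)c1ccccn1` gives 5.9 nM
- compound 2 `C/C(=N\NC(=S)Nc1ccc(I)cc1)c1ccccn1` gives 64 nM
- compound 3 `C/C(=N\NC(=S)Nc1ccc([N+](=O)[O-])cc1)c1ccccn1` gives 140 nM
- compound 4 `CC(=NNC(=S)Nc1ccc(I)cc1)c1ccccn1` has no value yet

These numbers come from a functional assay on T98G cells (Homo sapiens) for cytotoxicity, read by MTT assay, with a stated time of 48 h; on this read-out lower numbers stand for stronger inhibition and higher numbers for weaker inhibition. Compound 2, at 64 nM, is the second highest of the three measured numbers. Its smallest gap is a 2.2-fold higher number from compound 2 to compound 3 (0.34 log units; beyond the scatter), and its largest is an 11-fold higher number from compound 1 to compound 2 (1.04 log units; beyond the scatter).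

Compound 4 is compared with compound 2 through one structural difference: the two compounds have the same atoms and bonds; at least one stereo element is drawn with a configuration in one of them and without one in the other: 1 of 1 stereo elements differ; a double bond is drawn E in compound 2 and without a configuration in compound 4. The two compounds have the same atoms and bonds, and the iodo group is present in both.

The measured steps all swap one group on an aromatic carbon. Iodo in place of chloro gives the large step above, nitro in place of iodo gives the modest one, and nitro in place of chloro gives a 24-fold higher number from compound 1 to compound 3 (1.38 log units; beyond the scatter). All three lie beyond the scatter, but none of them involves a change in how a double bond is drawn. They offer no measured guide to such a change, and no group is swapped between compound 2 and compound 4.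

The expectation is therefore no step beyond the scatter, in either direction. The estimated step is no change at the digits printed from compound 2 to compound 4 (within the scatter). For compound 4 the estimated value is 64 nM, with an expected range from 30 nM to 135 nM.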

Compound 4, half-maximal inhibitory concentration: 64 nM
Compound 4: the middle estimate sits on the measured number at the digits printed; the range from low to high includes it.
By their numbers in this assay, from the lowest: compound 1; then compounds 2 and 4 (each within the scatter of the next); then compound 3.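

Until now, every step swapped one group on an aromatic carbon, and each moved the number beyond the scatter. Here no group changes, and this assay shows the first step with no movement at all (no change at the digits printed from compound 2 to compound 4 (within the scatter)), so the way the double bond is drawn is the one kind of difference in this set that leaves the number in place. This pair carries the iodo group on both sides and has the same atoms and bonds, which leaves only one thing separating them, a matter of how the structure is recorded: the fact that one of compounds 2 and 4 is drawn with a defined configuration and the other without, at the place where they differ.

The drawing alone does not tell whether the tested material of compound 4 is one form of the double bond or a mixture of forms, and a form drawn with the opposite configuration does not appear here to settle that question. On these data alone, it also remains open whether the same agreement would hold with the chloro group of compound 1, the nitro group of compound 3, or a bromo, fluoro or amino group on the same aromatic carbon.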